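This account rests on a few compounds, and the source may have more. Where it says the series, first, only, none or still open, it means among the compounds named here.

Measured compounds:
compound 1 `c1ccc(COc2ccc(COc3ccc(OCCOCCNC4CCCCC4)cc3)cc2)cc1` — 8080 nM
compound 2 `Nc1ccccc1COc1ccc(OCCOCCNC2CCCC2)cc1` — 14000 nM

In a functional assay on SK-OV-3 cells (Homo sapiens) for inhibition, read by CCK-8 assay, with a stated time of 70 h (a higher number here means a weaker inhibitor, a lower number a stronger inhibitor), compound 1 gives 8080 nM and compound 2 gives 14000 nM. Compound 2 has the higher of the two numbers, but the gap to compound 1 lies within the scatter, so no order between the two can be read from these values. Among the measured compounds shown here, no pair of measured compounds differs in only one place, so the size of a single structural change has not yet been tested by measurement.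

Compound 3 `O=[N+]([O-])c1ccccc1COc1ccc(OCCOCCNC2CCCC2)cc1` differs from compound 2 by nitro in place of amino on an aromatic carbon. The change sits on an aromatic carbon of a six-membered aromatic ring of carbon only, ortho to a large group; the rest of the molecule is unchanged. Neither measured compound tests this exchange, so the expectation rests on compound 2 alone. In this assay the step is expected to stay within the scatter, with no clear direction. Compound 3 is estimated at 12000 nM, with a range from 5000 nM to 30000 nM. The expected step is a 1.2-fold lower number from compound 2 to compound 3 (0.07 log units; within the scatter).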

Compound 3, half-maximal inhibitory concentration: 5370 nM
Compound 3: middle estimate off by 2.2-fold (0.35 log units), on the high side, within the range that was stated.
By their numbers in this assay, from the lowest: compounds 3, 1 and 2 (each within the scatter of the next, the first and the last beyond it).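

In this assay, among the compounds shown here, the exchange of 2-aminophenyl for 2-nitrophenyl gives a 2.6-fold lower number from compound 2 to compound 3 (0.42 log units; beyond the scatter) and this is the first single-place change that can be read, a modest step that lies beyond the scatter. It shows that this position, on an aromatic carbon ortho to a large group, is not indifferent to the group it carries: with the rest of the molecule unchanged, nitro gives the lower number and amino the higher one. Nothing at hand bears on what in the exchange produces the step.

Open, going by these compounds, is whether a nitrile, a trifluoromethyl or a carboxylic acid on the same aromatic carbon would fall with nitro or with amino, and whether the direction comes from nitro itself or from the loss of amino, a question that a plain hydrogen at this place would help to settle. Also open, on these data alone, is whether the step carries over when the cyclopentyl amine gives way to another amine or the ether chain to a longer chain.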